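The compounds below may be only part of what the source reports. "The series", "measured", "known", "first", "only" and "open" are said of these compounds alone.

Working notes on the series in an ADME assay on microsomes from liver (Rattus norvegicus) for metabolic stability; on this read-out higher numbers stand for a longer-lived compound and lower numbers for a shorter-lived compound. Compound 1 `N#Cc1ccc(NCCNc2ncc(-c3ncc[nH]3)c(-c3ccc(Cl)cc3Cl)n2)nc1` reaches the assay limit of > 0.5 h, a limit rather than a number. Compound 2 `FC(F)(F)c1ccc(NCCNc2ncc(-c3ncc[nH]3)c(-c3ccc(Cl)cc3Cl)n2)nc1` likewise gives a limit of > 0.5 h. Among the measured compounds shown here, the one single-point step, a step that the two limits leave unreadable from compound 1 to compound 2, is thus unreadable. Compound 3 `Nc1nc(NCCNc2ncc(-c3ncc[nH]3)c(-c3cc(F)ccc3F)n2)ccc1[N+](=O)[O-]` also gives only a limit, > 0.5 h. For the measured compounds named here, every value shown sits at the same limit (the limit of > 0.5 h in this assay, at which 3 of the 3 values shown sit), so no measured step yields a size. Compound 4 `Nc1nc(NCCNc2ncc(-c3ncc[nH]3)c(-c3cc(F)c(Cl)cc3Cl)n2)ccc1[N+](=O)[O-]` differs from compound 3 by 2,4-dichloro-5-fluorophenyl in place of 2,5-difluorophenyl on an aromatic carbon. Going by the values given here, no measured step bears on this change, and the one step available is unreadable. The expected step, a step that the limit leaves unreadable from compound 3 to compound 4, is none beyond the scatter. Compound 4 is estimated at 0.8 h, with a range from 0.4 h to 2 h.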

Compound 4, half-life: > 0.5 h
Compound 4: no number, only a limit; the forecaster's own chance of this, stated with the estimate: 75%; the middle value lies beyond the limit too.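

No step can be read between compound 3 and compound 4, since neither gives a number: the limit of > 0.5 h in this assay, at which 4 of the 4 values shown sit.

How far the half-life of any of these compounds extends in this assay, and whether 2,4-dichloro-5-fluorophenyl in place of 2,5-difluorophenyl alters it, remains open.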